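Trimming the side chain of compound 3

This account rests on a few compounds, and the source may have more. Where it says the series, first, only, none or still open, it means among the compounds named here.

Measured in an in vitro ADME assay on microsomes (Rattus norvegicus) for metabolic stability; on this read-out higher numbers stand for a longer-lived compound and lower numbers for a shorter-lived compound:
- Compound 1 `Cc1c2c(n3c1CCN(C(=O)CN)C[C@@H](C)[C@H](C)Nc1cc-3ccc1C(N)=O)CC(C)(C)CC2=O`: > 0.5 h, a limit
- Compound 2 `CC[C@H](N)C(=O)N1CCc2c(C)c3c(n2-c2ccc(C(N)=O)c(c2)N[C@@H](C)[C@H](C)C1)CC(C)(C)CC3=O`: > 0.5 h, a limit
- Compound 3 `Cc1c2c(n3c1CCN(C(=O)[C@@H](N)C(C)C)C[C@@H](C)[C@H](C)Nc1cc-3ccc1C(N)=O)CC(C)(C)CC2=O`: 0.217 h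

For the measured compounds named here, compound 3, at 0.217 h, holds the only exact number here. Compound 1 and compound 2 stand at the limit of > 0.5 h in this assay, at which 2 of the 3 values shown sit.

Compound 4 `Cc1c2c(n3c1CCN(C(=O)C(C)(C)N)C[C@@H](C)[C@H](C)Nc1cc-3ccc1C(N)=O)CC(C)(C)CC2=O` changes one group of compound 3: 1-amino-1-methylethyl in place of 1-amino-2-methylpropyl on a carbonyl carbon. In words, this is 1-amino-1-methylethyl in place of 1-amino-2-methylpropyl on a carbonyl carbon. Two measured steps change this same part of the molecule: an at least 2.3-fold lower number from compound 1 to compound 3 (0.36 log units; beyond the scatter) and an at least 2.3-fold lower number from compound 2 to compound 3 (0.36 log units; beyond the scatter). Going by the values given here, both end lower at compound 3, yet no measured compound carries the entering group, so they are only a loose guide. Read backwards, they suggest a modest rise in this assay. The expected change is a 1.8-fold higher number from compound 3 to compound 4 (0.27 log units; within the scatter). For compound 4 the estimate is 0.4 h, with an expected range of 0.2 h to 0.8 h.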

Compound 4, half-life: > 0.5 h
Compound 4: a limit, no number; the forecaster's own chance of this, stated with the estimate: 35%; middle value at least 1.2-fold (0.09 log units) away from the limit.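

In this assay the change from 1-amino-2-methylpropyl to 1-amino-1-methylethyl on this carbonyl carbon gives an at least 2.3-fold higher number from compound 3 to compound 4 (0.36 log units; beyond the scatter) and so shows that a branched group here can also sit clear of compound 3, not only aminomethyl or 1-aminopropyl. For the compounds shown here, compound 3 is now the only compound with an exact number, and the other three share one limit: the limit of > 0.5 h in this assay, at which 3 of the 4 values shown sit. The steps among compound 1, compound 2 and compound 4 cannot be read, as all three values are limits.

From the compounds shown here alone, how a longer chain or a carboxylic acid on this carbonyl carbon would behave stays open.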